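The source may report more compounds than this note shows. Statements on the series, on what has been measured and on what is new or still open speak of the compounds shown alone.

Compound 1 `CCCCCCCN1CC(=O)N(C)[C@@H](Cc2ccc(-c3cc(OC)c(OC)c(OC)c3)cc2)C1=O` gives 2300 nM in a functional assay for agonist activity at follicle-stimulating hormone receptor (Homo sapiens), read by a luciferase reporter (on this read-out higher numbers stand for an effect only at larger amounts of compound and lower numbers for an effect already at smaller amounts), and compound 2 `CCCCCCN1CC(=O)N(C)[C@@H](Cc2ccc(-c3cc(OC)c(OC)c(OC)c3)cc2)C1=O` gives 3000 nM. Among the compounds with values here, the single change between them, hydrogen in place of methyl on a saturated chain carbon six bonds along the chain from an amide-type nitrogen in a ring, gave a 1.3-fold higher number from compound 1 to compound 2 (0.12 log units; within the scatter). Compound 3 `CCCCCCN1C(=O)[C@H](Cc2ccc(-c3cc(OC)c(OC)c(OC)c3)cc2)N(C)C(=O)[C@@H]1C`, which adds methyl in place of hydrogen on a saturated ring carbon, gives 100 nM, the lowest of the three numbers, reached through a 30-fold lower number from compound 2 to compound 3 (1.48 log units; beyond the scatter). Compound 4 `CCCCCCCN1C(=O)[C@H](Cc2ccc(-c3cc(OC)c(OC)c(OC)c3)cc2)N(C)C(=O)[C@@H]1C` differs from compound 3 by methyl in place of hydrogen on a saturated chain carbon, six bonds along the chain from an amide-type nitrogen in a ring. This is the reverse of the change between compound 1 and compound 2, which stayed within the scatter, so no step beyond the scatter is expected in this assay, roughly a 1.3-fold lower number from compound 3 to compound 4 (0.10 log units; within the scatter). Compound 4 is therefore estimated at 80 nM, expected to fall between 40 nM and 200 nM.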

Compound 4, half-maximal effective concentration: 25 nM
The estimate for compound 4 lay 3.2-fold (0.51 log units) above the measured number; the whole stated range lies above it.
By their numbers in this assay, from the lowest: compound 4; then compound 3; then compounds 1 and 2 (each within the scatter of the next).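

In this assay, methyl in place of hydrogen at this chain position gave a 4.0-fold lower number from compound 3 to compound 4 (0.60 log units; beyond the scatter), so a chain change that stayed within the scatter on the core without the ring methyl does count on the core that carries it: the same change on two cores in this assay, a 1.3-fold higher number (0.12 log units; within the scatter) from compound 1 to compound 2 and a 4.0-fold higher number (0.60 log units; beyond the scatter) from compound 4 to compound 3, 3.1-fold (0.49 log units) apart, beyond the scatter of two such steps

The ring methyl likewise shows a larger step on the longer chain, with a 92-fold lower number from compound 1 to compound 4 (1.96 log units; beyond the scatter): the same change on two cores in this assay, a 30-fold lower number (1.48 log units; beyond the scatter) from compound 2 to compound 3 and a 92-fold lower number (1.96 log units; beyond the scatter) from compound 1 to compound 4, 3.1-fold (0.49 log units) apart, beyond the scatter of two such steps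

The two changes therefore do not add independently, and each counts for more when the other is present.

From the compounds shown here alone, whether a still longer chain, such as octyl, would lower the number further remains open. So does whether ethyl in place of the ring methyl, or an amine at the chain end, would keep this gain.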